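A few compounds are considered here, and "the series" means these few. Any claim that something is new, unique, unknown or untested is made for them only; others in the source may bear on it.

Working notes on the series. Three compounds share one core and differ in the aromatic substitution: compound 1 `C=CC[C@H]1C[C@]2([C@@H](C)Cc3ccc(OC)c(O)c3)OCOC2=CC1=O`, compound 2 `C=CC[C@H]1C[C@]2([C@@H](C)Cc3cc(N)c(OC)cc3F)OCOC2=CC1=O` and compound 3 `C=CC[C@H]1C[C@]2(C(C)Cc3cc(C(N)=O)c(OC)cc3F)OCOC2=CC1=O`. In a functional assay on M14 cells (Homo sapiens) for antiproliferative activity, with a stated time of 72 h (on this read-out lower numbers stand for stronger inhibition and higher numbers for weaker inhibition), compound 1 gives 8 nM, compound 2 gives 29 nM and compound 3 gives 4 nM. On these three numbers compound 2 stands highest, with compound 1 nearest and compound 3 furthest, both gaps beyond the scatter. The next compound is compound 4 `C=CC[C@H]1C[C@]2([C@@H](C)Cc3cc(O)c(OC)cc3F)OCOC2=CC1=O`, which carries a hydroxy in place of amino on an aromatic carbon. Among the compounds with values here, no measured pair shows this exact exchange. A moderate decrease in this assay is expected, not certainly beyond the scatter, since compound 1 with its hydroxy gives 8 nM. Compound 4 is estimated at 14 nM, range 5 nM to 40 nM, a step of a 2.1-fold lower number from compound 2 to compound 4 (0.32 log units; beyond the scatter) expected.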

Compound 4, half-maximal inhibitory concentration: 9 nM
The estimate for compound 4 lay 1.6-fold (0.19 log units) above the measured number; low and high end bracket the measured number.
By their numbers in this assay, from the lowest: compounds 3, 1 and 4 (each within the scatter of the next, the first and the last beyond it); then compound 2.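

In this assay, within the data shown here, hydroxy in place of amino on this aromatic carbon, ortho to a methoxy group, gives a 3.2-fold lower number from compound 2 to compound 4 (0.51 log units; beyond the scatter), the first direct reading of this exchange. Fluoro in place of hydrogen on an aromatic carbon gives a 1.1-fold higher number from compound 1 to compound 4 (0.05 log units; within the scatter), so with hydroxy present this exchange stays within the scatter. Nothing available accounts for either step. Open, going by these compounds, is how a methylamino group or a carboxylic acid on this aromatic carbon would read. Also open, on these data alone, is whether the fluoro exchange would stay within the scatter with amino in place of hydroxy.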